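Replacing the cyano-fluorophenyl of compound 3 with a pyrrolidinyl-pyridine

This account rests on a few compounds, and the source may have more. Where it says the series, first, only, none or still open, it means among the compounds named here.

Three thiazole acetic acids have been measured in an in vitro functional assay on HEK285-7 cells for antagonist activity at prostaglandin D2 receptor 2 (Homo sapiens), read by BRET and beta-arrestin recruitment; on this read-out higher numbers stand for weaker inhibition and lower numbers for stronger inhibition. Compound 1 `CCC(c1ccccc1)c1nc(-c2ccc(Cl)cc2)c(CC(=O)O)s1` gives > 100000 nM in this assay, a value that is a limit of the assay rather than a number (the limit of > 100000 nM in this assay, at which 1 of the 3 values shown sits). Compound 2 `O=C(O)Cc1sc(C(c2ccccc2)c2ccccc2)nc1-c1cccc(F)c1` gives 29 nM in this assay. Compound 3 `N#Cc1cc(-c2nc(C(c3ccc(F)cc3)c3ccc(F)cc3)sc2CC(=O)O)ccc1F` gives 520 nM in this assay, the higher of the two numbers shown, with compound 2 sitting lower by a gap beyond the usual scatter.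

Compound 4 `O=C(O)Cc1sc(C(c2ccc(F)cc2)c2ccc(F)cc2)nc1-c1ccnc(N2CCCC2)c1` has not yet been measured in this assay. It differs from compound 3 in one place: 2-(pyrrolidin-1-yl)pyridin-4-yl in place of 3-cyano-4-fluorophenyl on an aromatic carbon. For the measured compounds named here, no measured pair in this set follows the same change, so its effect cannot be read from the data. The account therefore expects a step of modest size in this assay, in either direction, with a lower number somewhat more likely; the estimated step is a 2.1-fold lower number from compound 3 to compound 4 (0.32 log units; beyond the scatter). On that basis compound 4 is expected to give about 250 nM in this assay, within a range from 50 nM to 1500 nM.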

Compound 4, half-maximal inhibitory concentration: > 100000 nM
Compound 4: only a limit was reported (the forecaster's own chance of this, stated with the estimate: 5%); at least 400-fold (2.60 log units) between middle value and limit.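

At the aromatic carbon next to the ring nitrogen, 2-(pyrrolidin-1-yl)pyridin-4-yl in place of 3-cyano-4-fluorophenyl gives an at least 190-fold higher number from compound 3 to compound 4 (2.28 log units; beyond the scatter) in this assay. For the compounds shown here, compound 4 gives > 100000 nM, which is a limit of the assay and not a number, and it is not alone there: the limit of > 100000 nM in this assay, at which 2 of the 4 values shown sit. No earlier pair isolated a change at this position, and this one shows that a change here alone, with the rest of the molecule held fixed, can take a compound from a measurable value to the limit.

The pyridine nitrogen and the pyrrolidine enter together, while the nitrile and the fluorine leave together, so the compounds shown do not tell which of these accounts for the step. An unsubstituted pyridin-4-yl, or a dimethylamino group in place of the pyrrolidine, would be needed to separate them.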